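The source may report more compounds than this note shows. Statements on the series, on what has been measured and on what is new or still open speak of the compounds shown alone.

Measured in a functional assay on HepG2 cells (Homo sapiens) for cytotoxicity, read by MTT assay, with a stated time of 24 h; on this read-out higher numbers stand for weaker inhibition and lower numbers for stronger inhibition:
- compound 1 `COc1cc(/C=C2\CN(C)C/C(=C\c3ccccc3F)C2=O)cc(OC)c1OC`: 670 nM
- compound 2 `COc1cc(/C=C2\CN(C)C/C(=C\c3ccc(Br)cc3)C2=O)cc(OC)c1`: 4840 nM
- compound 3 `COc1cc(/C=C2\CN(C)C/C(=C\c3ccc(F)cc3)C2=O)cc(OC)c1OC`: 7340 nM

Compound 3 lies within the scatter of compound 2, and its number is well above that of compound 1. Compound 4 `COc1cc(/C=C2\CN(C)C/C(=C\c3ccc(Br)cc3)C2=O)cc(OC)c1OC` differs from compound 3 by bromo in place of fluoro on an aromatic carbon. Going by the values given here, the one measured step, an 11-fold higher number from compound 1 to compound 3 (1.04 log units; beyond the scatter), is large but moves fluoro rather than replacing it, so its size does not carry over. Compound 2, at 4840 nM, bears the same 4-bromophenyl on a different core and is the closer guide. The expected step is a 1.5-fold lower number from compound 3 to compound 4 (0.17 log units; within the scatter), so nothing beyond the scatter is expected. The estimate for compound 4 is 5000 nM, with an expected range of 1800 nM to 13000 nM.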

Compound 4, half-maximal inhibitory concentration: 6800 nM
Beside the measured number, compound 4's estimate is 1.4-fold (0.13 log units) below it; the range from low to high includes it.
By their numbers in this assay, from the lowest: compound 1; then compounds 2, 4 and 3 (each within the scatter of the next).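

In this assay bromo in place of fluoro on the aromatic carbon para to a large group gives a 1.1-fold lower number from compound 3 to compound 4 (0.03 log units; within the scatter) and so leaves the read-out unmoved, with the halogen's identity making no measurable difference here. Methoxy in place of hydrogen on the other aromatic ring, a 1.4-fold higher number from compound 2 to compound 4 (0.15 log units; within the scatter) as well, also stays within the scatter. The gap to the 2-fluorophenyl compound persists with bromo, at a 10-fold higher number from compound 1 to compound 4 (1.01 log units; beyond the scatter) and beyond the scatter, so it is not specific to 4-fluorophenyl.

As far as these compounds go, whether an amine or a carboxylic acid at this position would shift the number remains open. No available evidence bears on what underlies these steps.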